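The source may hold more compounds than are shown below. What is called first, only, known or untested is meant among the compounds shown, and "the series" means these compounds.

Of the compounds shown here, three sharing one core have been measured in an ADME assay on Vero cells (Chlorocebus sabaeus) for cytotoxicity, read by MTT assay, with a stated time of 72 h; a lower number here means that less compound is tolerated, a higher number that more compound is tolerated. Compound 1 `Cc1ccccc1/C=N\NC(=S)N(Cc1ccccc1)Cc1ccccc1` gives 167000 nM. Compound 2 `C/C(=N/NC(=S)N(Cc1ccccc1)Cc1ccccc1)c1ccccc1` gives 167000 nM, and the step between these two is no change at the digits printed from compound 1 to compound 2 (within the scatter). Compound 3 `S=C(N/N=C\c1ccc(Cl)cc1)N(Cc1ccccc1)Cc1ccccc1` gives 159000 nM; the related steps are a 1.1-fold lower number from compound 1 to compound 3 (0.02 log units; within the scatter) and a 1.1-fold lower number from compound 2 to compound 3 (0.02 log units; within the scatter). Compound 2 therefore stands level with compound 1, the pair together carrying the highest of the three numbers, and compound 3 lies within the scatter of both.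

Compound 4 `C/C(=N/NC(=S)N(Cc1ccccc1)Cc1ccccc1)c1ccc([N+](=O)[O-])cc1` arises from compound 2 by one change: nitro in place of hydrogen on an aromatic carbon. The measured steps that bear on such a change are the two that alter the aromatic ring on the carbon with a double bond to nitrogen, a 1.1-fold lower number from compound 1 to compound 3 (0.02 log units; within the scatter) and a 1.1-fold lower number from compound 2 to compound 3 (0.02 log units; within the scatter), and neither left the scatter. The data give no instance of a nitro group, so the expectation rests on the ring changes alone. For compound 4 the expected step is a 1.0-fold lower number from compound 2 to compound 4 (0.02 log units; within the scatter), that is, no movement beyond the scatter. Compound 4 is accordingly estimated at 160000 nM, with a range from 90000 nM to 250000 nM.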

Compound 4, half-maximal cytotoxic concentration: < 150000 nM
Compound 4 ended at the assay's limit; the forecaster's own chance of this, stated with the estimate: 30%; middle value at least 1.0-fold (0.02 log units) away from the limit.
By their numbers in this assay, from the lowest: compounds 3, 1 and 2 (each within the scatter of the next). At a limit, below all of these: compound 4.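

In this assay compound 4 returns a limit and not a number: the limit of < 150000 nM in this assay, at which 1 of the 4 values shown sits. Nitro in place of hydrogen, para to a large group on the aromatic ring, is the only change shown that takes a value to this limit, and it reads as an at least 1.1-fold lower number from compound 2 to compound 4 (0.04 log units; that floor lies within the scatter). Only a floor for the step is therefore known, and that floor alone does not separate compound 4 from compound 2, whereas the earlier ring changes all gave plain numbers that could be compared directly.

Going by these compounds, how far past the limit compound 4 lies remains open. Also open, on these data alone, is whether an amine or a carboxylic acid in the same place on the ring would reach the limit too or stay level with compound 2.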